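A few compounds are considered here, and "the series" means these few. Any claim that something is new, unique, unknown or untested is made for them only; others in the source may bear on it.

Among the measured compounds shown here, the three compounds measured so far share one core and differ only in the group on one aromatic carbon. Compound 1 `Cc1nc(-c2cccc(C(=O)N3CCCC(C(=O)Nc4ccc(Cl)cc4)C3)c2)no1` carries a 5-methyl-1,2,4-oxadiazol-3-yl there, and in an ADME assay on PC-3 cells (Homo sapiens) for cytotoxicity, read by WST assay, tested at 100 uM (a lower number here means less inhibition, a higher number more inhibition at the concentration tested (going by the name of the read-out)), compound 1 gives 0%. Compound 2 `COC(=O)c1cccc(C(=O)N2CCCC(C(=O)Nc3ccc(Cl)cc3)C2)c1` has a methoxycarbonyl in that place, and compound 2 gives 0%. Compound 3 `CC(C)(C)CC(=O)Nc1cccc(C(=O)N2CCCC(C(=O)Nc3ccc(Cl)cc3)C2)c1` bears a (neopentylcarbonyl)amino, and compound 3 gives 0%. Every step among them, no change at the digits printed from compound 1 to compound 2 (within the scatter), no change at the digits printed from compound 1 to compound 3 (within the scatter) and no change at the digits printed from compound 2 to compound 3 (within the scatter), stays within the scatter, so compound 3 sits level with compounds 1 and 2, and none of the three can be called more or less cytotoxic than the others.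

Compound 4 `CSc1cccc(C(=O)N2CCCC(C(=O)Nc3ccc(Cl)cc3)C2)c1` is the next member of the series. The change from compound 3 is methylsulfanyl in place of (neopentylcarbonyl)amino on an aromatic carbon. The three measured steps all concern exchanges at this same aromatic carbon, each with no effect beyond the scatter, so nothing in the series suggests that this further exchange would move the read-out. The step of a number 2 percentage points higher from compound 3 to compound 4 (within the scatter) is therefore expected to lie within the scatter. For compound 4 the estimate in this assay is 2%, with a range from -8% to 15%.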

Compound 4, a percentage reported as inhibition, at one concentration (the size of the read-out at that concentration, not a potency): 0%
Estimate against measurement, compound 4: 2 percentage points above, and the stated range covers the measured number.
By their numbers in this assay, from the lowest: compounds 1, 2, 3 and 4 (each within the scatter of the next).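

In this assay the exchange of the (neopentylcarbonyl)amino for methylsulfanyl gives no change at the digits printed from compound 3 to compound 4 (within the scatter), which shows that going from a group of 8 heavy atoms with 1 hydrogen-bond donor to one of 2 heavy atoms with 0 hydrogen-bond donors leaves the read-out at this aromatic carbon within the scatter. Methylsulfanyl, the first group here to bring a sulfur to this place, also gives no change at the digits printed from compound 2 to compound 4 (within the scatter) when it stands in place of methoxycarbonyl and no change at the digits printed from compound 1 to compound 4 (within the scatter) when it stands in place of 5-methyl-1,2,4-oxadiazol-3-yl, so all four groups shown sit level at this position. No supporting data accompany these results that could explain this sameness.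

The compounds shown leave open whether an amine, a carboxylic acid or a longer chain on this aromatic carbon would give a reading in this assay that differs from these four. Since only this one place varies among them, they also leave open whether a change elsewhere on the shared core, such as replacing the chlorine, would move the read-out.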